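A second methoxy on compound 2

This account rests on a few compounds, and the source may have more. Where it says the series, first, only, none or still open, it means among the compounds named here.

Compound 1 `COc1ccc(C(CC(=O)O)NC(=O)c2cccc(C(=O)Nc3ccc4c(c3)CNCC4)c2)cc1OC` gives 11.6 nM
Compound 2 `COc1ccc(C(CC(=O)O)NC(=O)c2cc(C(=O)Nc3ccc4c(c3)CNCC4)cc([N+](=O)[O-])c2)cc1` gives 450 nM

In a functional assay on a cell-free system (plasma, Homo sapiens) for inhibition, with Plasma (Rattus norvegicus) as the target (on this read-out higher numbers stand for weaker inhibition and lower numbers for stronger inhibition), compound 2 at 450 nM has the higher of the two numbers and compound 1 stands at 11.6 nM. The gap between them lies beyond the scatter, and compound 2 is thus weaker. Among the compounds with values here, these two compounds differ in more than one place, and no measured pair isolates the next change. Compound 3 `COc1ccc(C(CC(=O)O)NC(=O)c2cc(C(=O)Nc3ccc4c(c3)CNCC4)cc([N+](=O)[O-])c2)cc1OC` arises from compound 2 through one change (methoxy in place of hydrogen on an aromatic carbon), methoxy in place of hydrogen on an aromatic carbon. Compound 1 at 11.6 nM also carries the 3,4-dimethoxyphenyl, which points to a lower number. The expected step is a 3.5-fold lower number from compound 2 to compound 3 (0.54 log units; beyond the scatter) and is estimated to lie beyond the scatter. Compound 3 is expected at 130 nM (range 35 nM to 450 nM).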

Compound 3, half-maximal inhibitory concentration: 340 nM
The estimate for compound 3 lay 2.6-fold (0.42 log units) below the measured number, and the stated range covers the measured number.
By their numbers in this assay, from the lowest: compound 1; then compounds 3 and 2 (each within the scatter of the next).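

In this assay the step is a 1.3-fold lower number from compound 2 to compound 3 (0.12 log units; within the scatter), so with the nitro group present, 4-methoxyphenyl and 3,4-dimethoxyphenyl cannot be told apart. With the 3,4-dimethoxyphenyl held constant, the nitro group gives a 29-fold higher number from compound 1 to compound 3 (1.47 log units; beyond the scatter), which isolates a large step at that aromatic carbon, where the earlier pair differed in two places. Still open, on these data alone, is whether the second methoxy counts for more on a core without the nitro group, and whether an amine or a nitrile on that carbon would stay close to compound 1. Nothing available gives a reason for either step.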